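Capping a Primary Amide with a Cyclobutyl Group

A few compounds are considered here, and "the series" means these few. Any claim that something is new, unique, unknown or untested is made for them only; others in the source may bear on it.

Compound 1 `Cn1ncc(Cl)c1-c1cc(C(=O)N[C@@H]2CN[C@H](CC(N)=O)C[C@H]2c2ccc(Cl)c(Cl)c2)oc1Cl` gives the lower of the two numbers recorded so far: in a functional assay on OVCAR-8 cells (Homo sapiens) for antiproliferative activity (a higher number here means a weaker inhibitor, a lower number a stronger inhibitor), compound 1 gives 1000 nM. Compound 2 `O=C(N[C@@H]1CNCC[C@H]1c1ccc(Cl)cc1)c1ccc(-c2ncnc3c2CCC3O)s1`, which shares only part of its build, gives 24100 nM in this assay, a gap beyond the usual scatter. Compound 3 `Cn1ncc(Cl)c1-c1cc(C(=O)N[C@@H]2CN[C@H](CC(=O)NC3CCC3)C[C@H]2c2ccc(Cl)c(Cl)c2)oc1Cl` differs from compound 1 in one place: cyclobutyl in place of hydrogen on an amide-type nitrogen. Within the data shown here, no measured pair shows this kind of change, so the expected step of a 1.1-fold lower number from compound 1 to compound 3 (0.05 log units; within the scatter) is small and without a clear direction, probably within the scatter. Compound 3 is therefore estimated at 900 nM, within a range of 300 nM to 2700 nM.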

Compound 3, half-maximal inhibitory concentration: 610 nM
The estimate for compound 3 lay 1.5-fold (0.17 log units) above the measured number, and the stated range covers the measured number.
By their numbers in this assay, from the lowest: compounds 3 and 1 (each within the scatter of the next); then compound 2.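

On the amide-type nitrogen, cyclobutyl in place of hydrogen gives a 1.6-fold lower number from compound 1 to compound 3 (0.21 log units; within the scatter) in this assay, so compound 1 and compound 3 cannot be told apart. This position therefore accepts a four-membered carbon ring, and the amide hydrogen that leaves is not needed to keep activity in this cell assay. No measurement shown offers a reason for this result.

This is a single pair, so it leaves open how far the position stretches. A larger ring such as cyclohexyl, or a chain ending in an amine or a carboxylic acid, could behave differently on the same nitrogen.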